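Extending an Alkoxy Chain in a Weakly Active Series

The source may report more compounds than this note shows. Statements on the series, on what has been measured and on what is new or still open speak of the compounds shown alone.

Three compounds share one core, and all were tested in a functional assay on DU-145 cells (Homo sapiens) for antiproliferative activity, read by sulforhodamine B assay, with a stated time of 72 h; on this read-out higher numbers stand for weaker inhibition of growth and lower numbers for stronger inhibition of growth. Compound 3 `CCOc1ccc2c(=O)cc(C(C)Br)oc2c1CBr` gives 20900 nM, the only result reported as a number. For compound 2 `COc1ccc2c(=O)cc(C(C)Br)oc2c1CBr` the result is a limit of the assay, > 26500 nM. For compound 1 `CCc1cc(=O)c2ccc(OC(C)C)c(CBr)c2o1` the result is likewise a limit, > 30700 nM. Compound 3 therefore stands as the single point of reference.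

Compound 4 `CC(C)Oc1ccc2c(=O)cc(C(C)Br)oc2c1CBr` differs from compound 3 in one spot: methyl in place of hydrogen on a saturated chain carbon bound to an oxygen on an aromatic ring and a saturated chain carbon. The closest comparison is the step of an at least 1.2-fold lower number from compound 2 to compound 3 (0.10 log units; that floor lies within the scatter), the same kind of change one bond nearer the ring, which gave a difference the scatter covers. Compound 1, which carries the isopropoxy chain that compound 4 would also carry, sits at a limit (the limit of > 30700 nM in this assay, at which 1 of the 3 values shown sits). From this, no change beyond the scatter is expected in this assay, so the step of a 1.1-fold higher number from compound 3 to compound 4 (0.02 log units; within the scatter) is the expected one. Compound 4 is expected to give 22000 nM, within a range from 8000 nM to 60000 nM, with a real chance that only a limit is reported.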

Compound 4, concentration for 50% growth inhibition: 15500 nM
Beside the measured number, compound 4's estimate is 1.4-fold (0.15 log units) above it, within the range that was stated.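

In this assay, the change from ethoxy to isopropoxy gives a 1.3-fold lower number from compound 3 to compound 4 (0.13 log units; within the scatter), so a methyl in place of hydrogen at this chain carbon leaves the growth read-out where it was, and compound 4 still gives a number. Compound 2 is a limit, so an at least 1.7-fold lower number from compound 2 to compound 4 (0.23 log units; that floor lies within the scatter) is only a floor for isopropyl in place of methyl on an oxygen on an aromatic ring: the limit of > 26500 nM in this assay, at which 1 of the 4 values shown sits. Compound 1 is also a limit, so an at least 1.9-fold lower number from compound 1 to compound 4 (0.29 log units; that floor lies within the scatter) is only a floor for bromo in place of hydrogen on a saturated chain carbon: the limit of > 30700 nM in this assay, at which 1 of the 4 values shown sits.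

Going by these compounds alone, every step here stays within the scatter, so this oxygen substituent has not yet been seen to matter. On these data alone, whether a longer chain such as butoxy, or a chain ending in an amine or a carboxylic acid, would shift the number beyond the scatter stays open.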